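Swapping the Nitrile for a Second Bromine

The compounds below may be only part of what the source reports. "The series", "measured", "known", "first", "only" and "open" are said of these compounds alone.

Compound 1 `Cc1nc(C#Cc2cc(C#N)cc([N+](=O)[O-])c2)cs1` and compound 2 `Cc1nc(C#Cc2cc(Br)cc(C#N)c2)cs1` share one core and differ at a single ring position. In a functional assay on HEK293 cells for antagonist activity at metabotropic glutamate receptor 5 (Rattus norvegicus), read by calcium flux (on this read-out lower numbers stand for stronger inhibition and higher numbers for weaker inhibition), compound 1 gives 2.63 nM, and compound 2 gives 1.06 nM. Putting bromo in place of nitro produced a 2.5-fold lower number from compound 1 to compound 2 (0.39 log units; beyond the scatter), so compound 2 holds the lower of the two numbers measured in this assay, with compound 1 as its only neighbor. Compound 3 `Cc1nc(C#Cc2cc(Br)cc(Br)c2)cs1` has not yet been measured; it differs from compound 2 in one place: bromo in place of cyano on an aromatic carbon. Within the data shown here, no measured step removes a cyano group, so the only step that bears on it is the one from compound 1 to compound 2, which also brought in bromo and was modest. Compound 3 is therefore expected to show a 1.1-fold higher number from compound 2 to compound 3 (0.05 log units; within the scatter), a step not clearly beyond the scatter. The estimate for compound 3 in this assay is 1.2 nM, with a range from 0.4 nM to 3.5 nM.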

Compound 3, half-maximal inhibitory concentration: 1.45 nM
The estimate for compound 3 lay 1.2-fold (0.08 log units) below the measured number; the measured number falls inside the stated range.
By their numbers in this assay, from the lowest: compounds 2, 3 and 1 (each within the scatter of the next, the first and the last beyond it).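

In this assay, the step is a 1.4-fold higher number from compound 2 to compound 3 (0.14 log units; within the scatter), so taking away the nitrile and putting bromo in its place leaves the number unchanged within normal repeat variation. Both earlier compounds carried the nitrile, so they could not show whether it was needed; compound 3 shows that this core can lose the nitrile, with its triple bond and its hydrogen-bond acceptor, and still read in the same range as compound 2. No measurement here explains why the two groups read alike.

The compounds shown place only nitrile, nitro and bromo on this ring, so it remains open how far this tolerance extends. An amine, a carboxylic acid or a plain hydrogen in the same place could read very differently.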